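The source may hold more compounds than are shown below. What is called first, only, known or untested is meant among the compounds shown, and "the series" means these compounds.

Working notes on the series.

Compound 1 `CCC(=O)O[C@@H]1CO[C@H]2[C@@H]1OC[C@@H]2OC(=O)c1ccccc1OC(C)=O` gives 0.0608 h in an ADME assay on a cell-free system (plasma, Homo sapiens) for metabolic stability, with Plasma (Rattus norvegicus) as the target, read by HPLC, at pH 7.4 (on this read-out lower numbers stand for a shorter-lived compound and higher numbers for a longer-lived compound), the highest of the three numbers in hand. Compound 2 `COc1ccc(C(=O)O[C@@H]2CO[C@H]3[C@@H]2OC[C@@H]3OC(=O)c2ccccc2OC(C)=O)cc1` gives 0.0525 h in this assay, and the step of a 1.2-fold lower number from compound 1 to compound 2 (0.06 log units; within the scatter) lies within the scatter, so the two cannot be ordered. Compound 3 `CC(=O)Oc1ccccc1C(=O)O[C@H]1CO[C@H]2[C@@H]1OC[C@H]2O[N+](=O)[O-]` gives 0.0144 h in this assay; the step of a 4.2-fold lower number from compound 1 to compound 3 (0.63 log units; beyond the scatter) is beyond the scatter, and compound 3 is the furthest from compound 1 in this set.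

Compound 4 `CC(=O)Oc1ccccc1C(=O)O[C@H]1CO[C@H]2[C@@H]1OC[C@H]2OC(=O)CCO[N+](=O)[O-]` is not yet measured. Against compound 1 the change is nitrooxy in place of hydrogen on a saturated chain carbon, two bonds along the chain from a carbonyl carbon. Within the data shown here, the only steps that bear on it are those in which a nitro enters on an oxygen on a saturated carbon: a 4.2-fold lower number from compound 1 to compound 3 (0.63 log units; beyond the scatter) and a 3.6-fold lower number from compound 2 to compound 3 (0.56 log units; beyond the scatter), both modest and both downward. Among the measured compounds shown here, in compound 4 the carbonyl remains and the nitrooxy sits on the chain, so those steps are only a partial guide; a step in this assay that is downward, but smaller than the one from compound 1 to compound 3 and possibly within the scatter, is expected. The estimate for compound 4 is therefore 0.04 h, with a range of 0.02 h to 0.08 h, which means an expected step of a 1.5-fold lower number from compound 1 to compound 4 (0.18 log units; within the scatter).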

Compound 4, half-life: 0.065 h
Compound 4: middle estimate off by 1.6-fold (0.21 log units), on the low side; low and high end bracket the measured number.
By their numbers in this assay, from the lowest: compound 3; then compounds 2, 1 and 4 (each within the scatter of the next).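

The a 1.1-fold higher number from compound 1 to compound 4 (0.03 log units; within the scatter) shows that in this assay nitrooxy can enter on this saturated chain carbon, two bonds along the chain from a carbonyl carbon, without a step beyond the scatter. The a 1.2-fold higher number from compound 2 to compound 4 (0.09 log units; within the scatter) likewise leaves 2-(nitrooxy)ethyl and 4-methoxyphenyl on the carbonyl carbon unresolved, so the half-life does not separate these two groups at that place. Among these compounds, the a 4.5-fold higher number from compound 3 to compound 4 (0.65 log units; beyond the scatter) adds what the earlier compounds could not show: the low number of compound 3 does not follow from the presence of a nitrooxy group alone, since with (2-(nitrooxy)ethyl)carbonyl on the same oxygen on a saturated carbon compound 4 stands well clear of compound 3 and level with compounds 1 and 2.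

Nothing shown explains why the two placements of the nitrooxy group give such different numbers. Also open, from the compounds shown here alone, is whether a longer chain carrying the nitrooxy group, or an amine or a carboxylic acid in its place on this chain carbon, would stay within the scatter of compound 4 or fall toward compound 3.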